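Fluoro to methoxy on the benzamide, carried to a second core

A few compounds are considered here, and "the series" means these few. Any claim that something is new, unique, unknown or untested is made for them only; others in the source may bear on it.

In a functional assay on HCT-116 cells (Homo sapiens) for cytotoxicity, read by sulforhodamine B assay, with a stated time of 48 h (a lower number here means a stronger inhibitor, a higher number a weaker inhibitor), compound 1 `CCCCNC(=O)N1Cc2c(NC(=O)c3ccc(F)cc3)nn(C(=O)c3ccccc3)c2C1` gives 30800 nM.
In this assay compound 2 `CCCCNC(=O)N1Cc2c(NC(=O)c3ccc(OC)cc3)nn(C(=O)c3ccccc3)c2C1` gives 25300 nM.
In this assay compound 3 `O=C(Nc1nn(C(=O)C2CC2)c2c1CN(C(=O)c1ccccc1)C2)c1ccc(F)cc1` gives 2280 nM.

Compounds 1 and 2 share a core and differ only by methoxy in place of fluoro on an aromatic carbon; the result was a 1.2-fold lower number from compound 1 to compound 2 (0.09 log units; within the scatter), so the two numbers are not distinguishable. Compound 3 has a different core; the difference between the two cores is not broken down here. Its number is the lowest of the three, and its gaps to compound 2 and to compound 1 both lie beyond the scatter.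

Compound 4 `COc1ccc(C(=O)Nc2nn(C(=O)C3CC3)c3c2CN(C(=O)c2ccccc2)C3)cc1` is not yet measured. It differs from compound 3 by methoxy in place of fluoro on an aromatic carbon, the same change as that from compound 1 to compound 2, at a place described in the same words. Going by the step seen on the first core, the step expected in this assay is a 1.2-fold lower number from compound 3 to compound 4 (0.08 log units; within the scatter), resting on a 1.2-fold lower number from compound 1 to compound 2 (0.09 log units; within the scatter). Compound 4 is therefore expected to give about 1900 nM, estimated to lie between 800 nM and 5000 nM.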

Compound 4, half-maximal inhibitory concentration: 5180 nM
The estimate for compound 4 lay 2.7-fold (0.44 log units) below the measured number, and the stated range ends below it.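

On the core of compound 3, methoxy in place of fluoro in this assay gives a 2.3-fold higher number from compound 3 to compound 4 (0.36 log units; beyond the scatter), a modest step that can be read as a real rise in the number. This does not match the step on the core of compound 1, so in this series the result of this change cannot simply be carried from one core to the other: the same change on two cores in this assay, a 1.2-fold lower number (0.09 log units; within the scatter) from compound 1 to compound 2 and a 2.3-fold higher number (0.36 log units; beyond the scatter) from compound 3 to compound 4, 2.8-fold (0.44 log units) apart, beyond the scatter of two such steps

The comparison rests on a single pair on each core, so it shows that the outcome depends on the core for these two pairs, but not which part of the core is responsible, nor whether the same would hold for any other replacement or a third core.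

The compounds shown leave open which of the features separating the two cores sets the difference between the steps. Also open, as far as these compounds go, is how a group other than fluoro or methoxy, such as an amine or a carboxylic acid, on the same aromatic carbon would behave on each core.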